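The compounds below may be only part of what the source reports. "The series", "measured", "known", "first", "only" and "open" are said of these compounds alone.

Measured in a functional assay on the whole organism with Mus musculus as the target; a higher number here means that more compound is needed for the effect, a lower number that less compound is needed:
Compound 1 `CN(c1ccncc1)n1cccc1`: > 20 mg/kg, a limit.
Compound 2 `CCc1cccn1N(C)c1ccncc1`: > 20 mg/kg, a limit.

Compound 2 gives no number and stands only at the limit of > 20 mg/kg in this assay, at which 2 of the 2 values shown sit. The change to compound 3 `CN(c1ccncc1)n1cccc1C#N` is cyano in place of ethyl on an aromatic carbon, next to the ring nitrogen (cyano in place of ethyl on an aromatic carbon). Among the measured compounds shown here, the one measured step, a step that the two limits leave unreadable from compound 1 to compound 2, has no readable size, so it sets no expected size or direction in this assay. The estimated step is a step that the limit leaves unreadable from compound 2 to compound 3, with no direction backed by measurement. Compound 3 is expected at 25 mg/kg, with an estimated range of 8 mg/kg to 60 mg/kg.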

Compound 3, dose for half-maximal effect: > 20 mg/kg
Compound 3 ended at the assay's limit (the forecaster's own chance of this, stated with the estimate: 65%); the middle value lies beyond the limit too.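

No step can be read among compound 1, compound 2 and compound 3, since all three give only a limit: the limit of > 20 mg/kg in this assay, at which 3 of the 3 values shown sit. The compounds shown leave open whether hydrogen, ethyl or cyano on that aromatic carbon changes the dose needed.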